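The source may report more compounds than this note shows. Statements on the series, on what has been measured and on what is new or still open speak of the compounds shown alone.

Of the compounds shown here, three share one core and have been tested in a functional assay on A549 cells (Homo sapiens) for inhibition, read by MTT assay; a lower number here means a stronger inhibitor, a higher number a weaker inhibitor. Compound 1 `CCCCCCCCn1cc(/C=C/C(=O)c2ccc(NC(=O)CN3CCN(c4ccccc4)CC3)cc2)nn1` gives 52400 nM. Compound 2 `CCCCCCCCCCn1cc(/C=C/C(=O)c2ccc(NC(=O)CN3CCN(c4ccccc4)CC3)cc2)nn1` gives 52100 nM, and compound 3 `O=C(CN1CCN(c2ccccc2)CC1)Nc1ccc(C(=O)/C=C/c2cn(Cc3ccc(Br)cc3)nn2)cc1` gives 42100 nM. All three numbers sit in a narrow band: the step of a 1.0-fold lower number from compound 1 to compound 2 (0.00 log units; within the scatter) and the step of a 1.2-fold lower number from compound 1 to compound 3 (0.10 log units; within the scatter) both lie within the scatter, as does the step of a 1.2-fold lower number from compound 2 to compound 3 (0.09 log units; within the scatter). Every measured change so far touches only the group on the triazole nitrogen, trading heptyl or nonyl for 4-bromophenyl, and none of those changes moves the number beyond the scatter.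

Compound 4 `CCCCCCCCn1cc(/C=C/C(=O)c2ccc(NC(=O)CN3CCN(c4ccccc4OC)CC3)cc2)nn1` differs from compound 1 at the other end of the molecule: methoxy in place of hydrogen on an aromatic carbon, which reads as phenyl to 2-methoxyphenyl. Within the data shown here, no measured step touches this ring, so nothing in the data speaks for or against a shift there. With the three measured numbers so close together, the expectation is a step of a 1.1-fold lower number from compound 1 to compound 4 (0.04 log units; within the scatter) in this assay that stays within the scatter. Compound 4 is therefore estimated at 48000 nM, in a range from 20000 nM to 110000 nM.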

Compound 4, half-maximal inhibitory concentration: 34000 nM
The estimate for compound 4 lay 1.4-fold (0.15 log units) above the measured number; the measured number falls inside the stated range.
By their numbers in this assay, from the lowest: compounds 4, 3, 2 and 1 (each within the scatter of the next).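

Placing methoxy on the phenyl ring, on an aromatic carbon ortho to a large group, gives the first measured change at this end of the molecule. In this assay, phenyl to 2-methoxyphenyl gives a 1.5-fold lower number from compound 1 to compound 4 (0.19 log units; within the scatter), so this carbon takes the added group without a shift beyond the scatter, just as the changes at the other end left the number within it. No supporting data are available here to explain this result.

As far as these compounds go, whether a hydroxyl, a fluorine or a dimethylamino group on this same carbon would move the number beyond the scatter remains open. From the compounds shown here alone, it is also open whether methoxy would give a similar result alongside the 4-bromophenyl group of compound 3.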